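The source may report more compounds than this note shows. Statements on the series, on what has been measured and on what is new or still open speak of the compounds shown alone.

Compound 1, `C[C@@H]1CC[C@@H](Oc2cc(-c3ccccc3)ccn2)CN1C(=O)c1ccccc1-n1nccn1`, gives 45 nM in a functional assay on CHO-K1 cells for antagonist activity at Orexin receptor type 2 (Homo sapiens), read by FLIPR and calcium flux; a lower number here means a stronger inhibitor, a higher number a weaker inhibitor.
Compound 2, `C[C@@H]1CC[C@@H](Oc2cc(Br)ccn2)CN1C(=O)c1ccccc1-n1nccn1`, gives 10 nM in this assay.
Compound 3, `CC(C)OC(=O)c1ccccc1C(=O)N1C[C@H](Oc2cc(C#N)ccn2)CC[C@H]1C`, gives 38 nM in this assay.

Among these three numbers, compound 1 has the highest value in this assay. Compound 3 lies nearest to it, and the gap between them falls within the scatter, so no order between compound 1 and compound 3 can be read from these two values. Compound 2 lies furthest from compound 1: a 4.5-fold lower number from compound 1 to compound 2 (0.65 log units; beyond the scatter), a modest step beyond the scatter.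

The unmeasured compound 4, `COC(=O)c1ccnc(O[C@@H]2CC[C@@H](C)N(C(=O)c3ccccc3-n3nccn3)C2)c1`, differs from compound 1 in one place: methoxycarbonyl in place of phenyl on an aromatic carbon.

Among the measured compounds shown here, the only measured step that bears on this change is the one from compound 1 to compound 2, where a smaller substituent took the place of the phenyl group on the same aromatic carbon and the number fell by a modest amount. In compound 4 the phenyl is again replaced by a smaller group, so a step in the same direction, of about that size or somewhat less, is expected in this assay. The estimated step is a 1.8-fold lower number from compound 1 to compound 4 (0.26 log units; within the scatter). Compound 4 is therefore expected to give about 25 nM in this assay, within a range from 10 nM to 60 nM.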

Compound 4, half-maximal inhibitory concentration: 22 nM
Compound 4: the middle estimate sits 1.1-fold (0.06 log units) above what was measured, and the stated range covers the measured number.
By their numbers in this assay, from the lowest: compound 2; then compounds 4, 3 and 1 (each within the scatter of the next, the first and the last beyond it).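

The new result shows that bromo is not the only replacement for phenyl on this aromatic carbon, opposite the ring nitrogen, that gives a lower number. In this assay, methoxycarbonyl, which has no ring and brings 2 hydrogen-bond acceptors, also lowers the number beyond the scatter (a 2.0-fold lower number from compound 1 to compound 4 (0.31 log units; beyond the scatter)). Among the compounds shown here, the two replacements do not give the same result, however, and the methoxycarbonyl group leaves the number higher than bromo does (a 2.2-fold higher number from compound 2 to compound 4 (0.34 log units; beyond the scatter)), so compound 2 remains below both compound 1 and compound 4 in this series, where only this one place changes. No measurement shown here offers an explanation for either step.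

The compounds shown leave open which feature of these groups matters, as the change from phenyl to methoxycarbonyl removes the aromatic ring, reduces the heavy atoms and adds the carbonyl all at once. As far as these compounds go, it also remains open where a carboxylic acid, a primary amide, an amine or a longer ester such as ethoxycarbonyl would fall on this carbon relative to bromo and methoxycarbonyl.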